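A few compounds are considered here, and "the series" means these few. Any claim that something is new, unique, unknown or untested is made for them only; others in the source may bear on it.

Working notes on the series. Compound 1 `CCn1ccc2cc(NC(=O)CN(c3cc(Cl)ccc3OC)S(=O)(=O)c3ccccc3)ccc21` gives 2220 nM in a functional assay on SH-SY5Y cells (Homo sapiens), read by MTT assay, with a stated time of 24 h; a higher number here means that more compound is needed for the effect, a lower number that less compound is needed. Compound 2 `COc1ccc(NC(=O)CN(c2cc(Cl)ccc2OC)S(=O)(=O)c2ccccc2)cc1OC` reaches only the limit of > 20000 nM in this assay. Compound 3 `COc1ccc(Cl)cc1N(CC(=O)N1CCc2ccccc21)S(=O)(=O)c1ccccc1` likewise shows only the limit of > 20000 nM in this assay; its position among the measured numbers is therefore unreadable, and the limit of > 20000 nM in this assay, at which 2 of the 3 values shown sit, applies to it. Compound 4 `COc1ccc(CNC(=O)CN(c2cc(Cl)ccc2OC)S(=O)(=O)c2ccccc2)cc1` differs from compound 3 in that ((4-methoxybenzyl)amino in place of 2,3-dihydro-1H-indol-1-yl on a carbonyl carbon). Among the measured compounds shown here, the steps that bear on this change are a step that the two limits leave unreadable from compound 2 to compound 3 and, for a change on the amide-type nitrogen, an at least 9.0-fold higher number from compound 1 to compound 2 (0.95 log units; beyond the scatter). Neither gives a readable direction for compound 4 in this assay; a step not clearly beyond the scatter is expected, a number no higher from compound 3 to compound 4 (the limit leaves the size open). Compound 4 is thus estimated at 20000 nM, between 5000 nM and 80000 nM.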

Compound 4, half-maximal effective concentration: > 20000 nM
Compound 4 ended at the assay's limit; the forecaster's own chance of this, stated with the estimate: 60%; the middle value sits exactly at the limit.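

Among the compounds shown here, with 4-methoxybenzyl in place of 1-ethyl-1H-indol-5-yl on the amide-type nitrogen, this assay gives an at least 9.0-fold higher number from compound 1 to compound 4 (0.95 log units; beyond the scatter), so compound 2 is no longer the only replacement of that group to fall short of compound 1. Compound 4 gives only a limit, > 20000 nM. The steps to compound 4 from compound 2 and from compound 3 cannot be read, and the series now gathers at one value: the limit of > 20000 nM in this assay, at which 3 of the 4 values shown sit.

What the ethyl group itself contributes stays open, since no compound shown changes it alone. A methyl or propyl group in its place on the 1-ethyl-1H-indol-5-yl would address this.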